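Swapping a methoxy for a bromine on the aniline ring

The source may report more compounds than this note shows. Statements on the series, on what has been measured and on what is new or still open speak of the compounds shown alone.

The measured compounds and their values:
compound 1, `COc1ccc(Nc2cc(C)nc(SCc3nc4ccccc4[nH]3)n2)cc1`: 69800 nM
compound 2, `COc1ccccc1Nc1cc(C)nc(SCc2nc3ccccc3[nH]2)n1`: 34400 nM
compound 3, `Cc1cc(N(C)Cc2ccccc2)nc(SCc2nc3ccccc3[nH]2)n1`: > 100000 nM, a limit of the assay rather than a number

In a functional assay on ECa-109 cells (Homo sapiens) for cytotoxicity, read by MTT assay, with a stated time of 72 h (a lower number here means a stronger inhibitor, a higher number a weaker inhibitor), compound 2 gives the lowest of the two numbers, with compound 1 one step away: a 2.0-fold lower number from compound 1 to compound 2 (0.31 log units; beyond the scatter). For compound 3 this assay reports only a limit, (the limit of > 100000 nM in this assay, at which 1 of the 3 values shown sits). Compound 4, `Cc1cc(Nc2ccc(Br)cc2)nc(SCc2nc3ccccc3[nH]2)n1`, differs from compound 2 by 4-bromophenyl in place of 2-methoxyphenyl on a nitrogen on an aromatic ring. Among the compounds with values here, the one measured step that bears on this is the move of the methoxy group between two places on its ring, a 2.0-fold lower number from compound 1 to compound 2 (0.31 log units; beyond the scatter), read in reverse; no measured pair shows what a bromine in place of a methoxy does. A modest rise is therefore expected, a 1.7-fold higher number from compound 2 to compound 4 (0.24 log units; within the scatter). Compound 4 is estimated at 60000 nM, within a range from 25000 nM to 150000 nM.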

Compound 4, half-maximal inhibitory concentration: 42900 nM
The estimate for compound 4 lay 1.4-fold (0.15 log units) above the measured number; the measured number falls inside the stated range.
By their numbers in this assay, from the lowest: compounds 2, 4 and 1 (each within the scatter of the next, the first and the last beyond it). At a limit, above all of these: compound 3.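

In this assay, bromo in place of methoxy on the aromatic carbon makes no clear difference, a 1.6-fold lower number from compound 1 to compound 4 (0.21 log units; within the scatter), and neither does 4-bromophenyl in place of 2-methoxyphenyl, a 1.2-fold higher number from compound 2 to compound 4 (0.10 log units; within the scatter). So this ring can carry a bromine as well as a methoxy with no change beyond the scatter, whereas moving from benzyl(methyl)amino does clearly shift the number, an at least 2.3-fold lower number from compound 3 to compound 4 (0.36 log units; beyond the scatter). Compound 3 stands at a limit of the assay, not at a number: the limit of > 100000 nM in this assay, at which 1 of the 4 values shown sits.

Still open, going by these compounds, is whether a quite different group on this ring, such as a carboxylic acid or a dimethylamino group, would move the number beyond the scatter.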